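Moving a formyl group: what to expect of compound 4

The source may report more compounds than this note shows. Statements on the series, on what has been measured and on what is new or still open speak of the compounds shown alone.

Measured in a functional assay on HepG2 cells (Homo sapiens) for inhibition, read by MTT assay, with a stated time of 48 h (a lower number here means a stronger inhibitor, a higher number a weaker inhibitor), as half-maximal inhibitory concentration
- compound 1 `COc1cc(C(=O)/C=C/c2ccc(O)cc2)cc(OC)c1OC` gives 16000 nM
- compound 2 `COc1cc(C(=O)/C=C/c2cccc(O)c2)cc(OC)c1OC` gives 94000 nM
- compound 3 `COc1cc(C(=O)/C=C/c2ccccc2C=O)cc(OC)c1OC` gives > 100000 nM which is a limit and not a number

Compound 3 sits at > 100000 nM and that value is only a limit. Compound 4 `COc1cc(C(=O)/C=C/c2cccc(C=O)c2)cc(OC)c1OC` has the same atoms joined differently (3-formylphenyl in place of 2-formylphenyl on a double-bonded chain carbon bound to a double-bonded chain carbon). For the measured compounds named here, two measured steps bear on this change. Shifting a hydroxyl group on the ring gave a 5.9-fold higher number from compound 1 to compound 2 (0.77 log units; beyond the scatter) so such a shift can matter. The other step is an at least 1.0-fold higher number from compound 2 to compound 3 (0.02 log units; that floor lies within the scatter) and its floor lies within the scatter. Compound 4 is therefore expected to stay weak, near compound 2 at 94000 nM in this assay without a firm direction. The expected step is an at least 1.2-fold lower number from compound 3 to compound 4 (0.09 log units; that floor lies within the scatter) and it stays small. For compound 4 the estimated value is 80000 nM within an expected range from 30000 nM to 150000 nM in this estimate.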

Compound 4, half-maximal inhibitory concentration: > 100000 nM
Compound 4 gave a limit, no number; the forecaster's own chance of this, stated with the estimate: 45%; at least 1.2-fold (0.09 log units) between middle value and limit.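

In this assay compound 4 gives only a limit, > 100000 nM, so 3-formylphenyl in place of 2-formylphenyl still yields no number, and the step between these two compounds cannot be read. Formyl in place of hydroxy on an aromatic carbon gives an at least 1.0-fold higher number from compound 2 to compound 4 (0.02 log units; that floor lies within the scatter), while 3-formylphenyl in place of 4-hydroxyphenyl gives an at least 6.2-fold higher number from compound 1 to compound 4 (0.79 log units; beyond the scatter). Neither formyl compound shown gives a readable value: the limit of > 100000 nM in this assay, at which 2 of the 4 values shown sit.

From the compounds shown here alone, whether an amine or a carboxylic acid in place of the formyl group of compound 4 would give a readable number stays open.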